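Swapping a trifluoromethyl for chloro on a urea-linked ring

This account rests on a few compounds, and the source may have more. Where it says the series, first, only, none or still open, it means among the compounds named here.

Of the compounds shown here, three sharing one core have been tested in a functional assay on HCT-116 cells (Homo sapiens) for inhibition, read by sulforhodamine B assay, with a stated time of 48 h, tested at 10 uM; a lower number here means a stronger effect, a higher number a weaker effect of the compound at the concentration tested. Compound 1, `COc1cc(Cl)cc(-c2nn(-c3cccc(NC(=O)c4ccc(Cl)c(Cl)c4)c3)cc2-c2ccncc2)c1`, gives 44.1%. Compound 2, `O=C(Nc1cccc(-n2cc(-c3ccncc3)c(-c3cc(O)cc(Cl)c3)n2)c1)Nc1ccc(Cl)c(Cl)c1`, gives -57.3%. Compound 3, `COc1cc(Cl)cc(-c2nn(-c3cccc(NC(=O)Nc4ccc(Cl)c(C(F)(F)F)c4)c3)cc2-c2ccncc2)c1`, gives 3.39%, which places it second highest of the three numbers, well apart from both neighbours. Among the measured compounds shown here, the only single-place step measured so far is a number 40.7 percentage points lower from compound 1 to compound 3 (beyond the scatter), and that step changes two things at once, the linker and the ring substituent.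

Compound 4, `COc1cc(Cl)cc(-c2nn(-c3cccc(NC(=O)Nc4ccc(Cl)c(Cl)c4)c3)cc2-c2ccncc2)c1`, differs from compound 3 by chloro in place of trifluoromethyl on an aromatic carbon. For the measured compounds named here, no measured step isolates a chloro against a trifluoromethyl, so the size and direction of the change in this assay are open. Compound 2, which carries the same (3,4-dichlorophenyl)amino urea as compound 4 but a hydroxy on the other ring, shows a far lower number than compound 3, which gives some weight to a lower reading. Compound 4 is therefore estimated at -10%, within -50% to 30%. This corresponds to an expected step of a number 13.4 percentage points lower from compound 3 to compound 4 (beyond the scatter), with wide uncertainty.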

Compound 4, a percentage reported as activity, at one concentration (the size of the read-out at that concentration, not a potency): 9.22%
Beside the measured number, compound 4's estimate is 19.2 percentage points below it; the range from low to high includes it.
By their numbers in this assay, from the lowest: compound 2; then compounds 3 and 4 (each within the scatter of the next); then compound 1.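

In this assay, putting chloro in place of trifluoromethyl on the urea-linked ring gives a number 5.8 percentage points higher from compound 3 to compound 4 (within the scatter), so the two groups cannot be told apart at this position in this assay. The large differences come from changes elsewhere: a number 34.9 percentage points lower from compound 1 to compound 4 (beyond the scatter) goes with (3,4-dichlorophenyl)amino in place of 3,4-dichlorophenyl on the carbonyl carbon, and a number 66.5 percentage points higher from compound 2 to compound 4 (beyond the scatter) goes with methyl in place of hydrogen on the oxygen on the aromatic ring. Nothing at hand explains any of these differences.

Going by these compounds, whether a nitrile or a bromo at the same position would read like chloro and trifluoromethyl remains open. On these data alone, it is also open whether the hydroxy seen in compound 2 would keep its large effect alongside the 4-chloro-3-(trifluoromethyl)phenyl ring.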